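A few compounds are considered here, and "the series" means these few. Any claim that something is new, unique, unknown or untested is made for them only; others in the source may bear on it.

Compound 3 `CC(=O)Nc1ccc(S(=O)(=O)Oc2ccccc2C(C)C)cc1` gives 23000 nM in a functional assay on HT-29 cells (Homo sapiens) for antiproliferative activity, read by sulforhodamine B assay, with a stated time of 48 h (a higher number here means a weaker inhibitor, a lower number a stronger inhibitor), the highest of the three numbers recorded there. Compound 1 `CC(C)c1ccccc1OS(=O)(=O)c1cccc(NC(=O)C(C)(C)C)c1` gives 19000 nM, within the scatter of compound 3, while compound 2 `CC(C)c1ccccc1OS(=O)(=O)c1cccc(NC(=O)CCl)c1` gives 4500 nM. For the measured compounds named here, the only step between neighbours, a 4.2-fold lower number from compound 1 to compound 2 (0.63 log units; beyond the scatter), concerns a different group on the carbonyl carbon and so bears only loosely on what follows. Compound 4 `CCCNC(=O)Nc1ccc(S(=O)(=O)Oc2ccccc2C(C)C)cc1` differs from compound 3 by propylamino in place of methyl on a carbonyl carbon. Going by the values given here, no measured step shows what a propylamino on that carbon does; the shared core otherwise gives numbers close to those of compound 3 and compound 1. Compound 4 is therefore expected to show a step of a 1.2-fold lower number from compound 3 to compound 4 (0.06 log units; within the scatter), an estimate of 20000 nM with a range from 8000 nM to 50000 nM.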

Compound 4, half-maximal inhibitory concentration: 6300 nM
For compound 4 the middle estimate is 3.2-fold (0.50 log units) above the measured one; the measured number lies below the stated range.
By their numbers in this assay, from the lowest: compounds 2 and 4 (each within the scatter of the next); then compounds 1 and 3 (each within the scatter of the next).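

In this assay, propylamino in place of methyl on a carbonyl carbon, which turns acetamido into (propylcarbamoyl)amino, gives a 3.7-fold lower number from compound 3 to compound 4 (0.56 log units; beyond the scatter), a step beyond the scatter. The earlier compounds shown here showed a change on a carbonyl carbon only for chloromethyl in place of tert-butyl, whereas this step shows that a group carrying nitrogen on that carbon also lowers the number. No evidence given here accounts for this step. Going by these compounds, whether the nitrogen or the chain length matters stays open. Methylamino or a butyl chain on that carbon would separate the two.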